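Chloro substitution in the biphenyl-pyridazinyl pyrazoline series

The source may hold more compounds than are shown below. What is called first, only, known or untested is meant among the compounds shown, and "the series" means these compounds.

Compound 1 `c1ccc(C2=NN(c3ccc(-c4ccccc4)nn3)C(c3ccccc3)C2)cc1` gives 23800 nM in a functional assay on MCF7 cells (Homo sapiens) for antiproliferative activity, read by MTT assay, with a stated time of 24 h (on this read-out lower numbers stand for stronger inhibition and higher numbers for weaker inhibition), the lowest of the two numbers recorded. Compound 2 `Clc1ccc(C2CC(c3ccccc3)=NN2c2ccc(-c3ccccc3)nn2)cc1` gives 100000 nM in this assay. Compound 3 `COc1ccc(C2CC(c3ccccc3)=NN2c2ccc(-c3ccccc3)nn2)c(OC)c1` returns only a limit of the assay, > 100000 nM, and not a number; this is the limit (the limit of > 100000 nM in this assay, at which 1 of the 3 values shown sits). The step from compound 1 to compound 2 reads a 4.2-fold higher number from compound 1 to compound 2 (0.62 log units; beyond the scatter), and the step to the dimethoxy compound reads an at least 4.2-fold higher number from compound 1 to compound 3 (0.62 log units; beyond the scatter); between compound 2 and compound 3 the step of a number no lower from compound 2 to compound 3 (the limit leaves the size open) cannot be sized.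

Compound 4 `Clc1ccc(C2=NN(c3ccc(-c4ccccc4)nn3)C(c3ccccc3)C2)cc1` differs from compound 1 in one place: chloro in place of hydrogen on an aromatic carbon. Within the data shown here, the only measured step with the same kind of change is the one from compound 1 to compound 2, a modest move toward a higher number, on a phenyl attached to the saturated ring carbon rather than the one at the carbon–nitrogen double bond. On that basis a modest step toward a higher number is expected in this assay, of roughly the size seen for compound 2, though the different attachment leaves the size loose. The expected step is estimated as a 2.5-fold higher number from compound 1 to compound 4 (0.40 log units; beyond the scatter). Compound 4 is therefore estimated at 60000 nM, with a range from 20000 nM to 150000 nM; a reading that only reaches the limit of the assay is possible.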

Compound 4, half-maximal inhibitory concentration: 10000 nM
Compound 4: the middle estimate sits 6.0-fold (0.78 log units) above what was measured; measured number below the stated range.
By their numbers in this assay, from the lowest: compound 4; then compound 1; then compound 2.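

Chloro in place of hydrogen on this phenyl, para to a large group, gives a 2.4-fold lower number from compound 1 to compound 4 (0.38 log units; beyond the scatter) in this assay. The same exchange, phenyl to 4-chlorophenyl, on the other phenyl of the core gives a 4.2-fold higher number from compound 1 to compound 2 (0.62 log units; beyond the scatter), so the two steps from compound 1 run in opposite directions, and the outcome of this change in the series depends on which phenyl carries the chloro. This is the first change shown that moves the number downward from compound 1, since compound 2 and compound 3 both lie on the higher side, though the step to compound 4 remains modest. No measurement shown bears on why the two steps differ in direction.

Only chloro has been seen at this position, so a single example cannot say whether the lower number belongs to chloro alone or would extend to other groups, such as a bromo, an amine or a carboxylic acid. Also open is whether chloro on both phenyl rings together would follow either step, as no such compound is among those shown.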